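Amide Aryl Replacement in the Aminothiazole Series: Compound 4

A few compounds are considered here, and "the series" means these few. Any claim that something is new, unique, unknown or untested is made for them only; others in the source may bear on it.

Measured so far in an assay on brain for displacement of a labelled ligand from D(3) dopamine receptor (Rattus norvegicus); a higher number here means a weaker inhibitor, a lower number a stronger inhibitor:
compound 1 `CCCN(CC[C@H]1CC[C@H](NC(=O)/C=C/c2ccc(Cl)cc2)CC1)[C@H]1CCc2nc(N)sc2C1` gives 2.5 nM
compound 2 `CCCN(CC[C@H]1CC[C@H](NC(=O)/C=C/c2ccccc2OC)CC1)[C@H]1CCc2nc(N)sc2C1` gives 8.1 nM
compound 3 `CCCN(CC[C@H]1CC[C@H](NC(=O)c2ccc3ccccc3n2)CC1)[C@H]1CCc2nc(N)sc2C1` gives 1.6 nM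

Compound 3 holds the lowest of the three numbers, though its separation from compound 1 is a 1.6-fold lower number from compound 1 to compound 3 (0.19 log units; within the scatter) and so within the scatter, while against compound 2 it shows a 5.1-fold lower number from compound 2 to compound 3 (0.70 log units; beyond the scatter), beyond the scatter.

Compound 4 `CCCN(CC[C@H]1CC[C@H](NC(=O)c2ccc(-c3noc(C)n3)cc2)CC1)[C@H]1CCc2nc(N)sc2C1` differs from compound 3 at the amide: 4-(5-methyl-1,2,4-oxadiazol-3-yl)phenyl in place of quinolin-2-yl on a carbonyl carbon.

For the measured compounds named here, no measured step exchanges one aryl group directly on the carbonyl carbon for another, so the relevant steps are those in which the quinolin-2-yl group entered, a 1.6-fold lower number from compound 1 to compound 3 (0.19 log units; within the scatter) and a 5.1-fold lower number from compound 2 to compound 3 (0.70 log units; beyond the scatter), and the change of aryl group within the ethenyl-linked pair, a 3.2-fold higher number from compound 1 to compound 2 (0.51 log units; beyond the scatter). All three are modest or within the scatter, so the change of aryl group at this position is expected to move the number only modestly, most likely upward from the lowest value in the set.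

Compound 4 is therefore expected to give 4.5 nM in this assay, with a range from 1.5 nM to 14 nM. The step this implies, a 2.8-fold higher number from compound 3 to compound 4 (0.45 log units; beyond the scatter), is expected to be a small loss relative to compound 3.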

Compound 4, inhibition constant: 1.3 nM
Beside the measured number, compound 4's estimate is 3.5-fold (0.54 log units) above it; measured number below the stated range.
By their numbers in this assay, from the lowest: compounds 4, 3 and 1 (each within the scatter of the next); then compound 2.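

In this assay, 4-(5-methyl-1,2,4-oxadiazol-3-yl)phenyl replaces quinolin-2-yl on the carbonyl carbon with a 1.2-fold lower number from compound 3 to compound 4 (0.09 log units; within the scatter), so this position accepts an exchange of one aryl group for another, even one with more heavy atoms and hydrogen-bond acceptors, without a change beyond the scatter. The entering group also stands within the scatter of the 2-(4-chlorophenyl)ethenyl amide, a 1.9-fold lower number from compound 1 to compound 4 (0.28 log units; within the scatter), but apart from the 2-(2-methoxyphenyl)ethenyl amide, a 6.2-fold lower number from compound 2 to compound 4 (0.79 log units; beyond the scatter), which leaves compound 2 as the only one of the four set apart. No supporting data bear on why the number holds across this change.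

Still open, going by these compounds, is whether a plain phenyl, or a phenyl carrying a carboxylic acid or an amine in place of the 5-methyl-1,2,4-oxadiazol-3-yl group, would hold the number in this range. The compounds shown also say nothing about how these amides behave at any other receptor.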